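This account rests on a few compounds, and the source may have more. Where it says the series, first, only, none or still open, it means among the compounds named here.

Series notes, cytotoxicity. For the measured compounds named here, in an ADME assay on WI-38 cells (Homo sapiens) for cytotoxicity, read by MTT assay, with a stated time of 72 h (a higher number here means a weaker inhibitor, a lower number a stronger inhibitor), compound 2 `O=C(CCc1cccc2c1B(O)OC2)Nc1ccc(F)cc1` gives 12000 nM, the only full number in the set so far. Compound 1 `O=C(CCc1cccc2c1B(O)OC2)NC1CCCCC1`, which carries cyclohexyl on the amide-type nitrogen, reaches only the limit of > 100000 nM in this assay; the limit is a boundary of this assay rather than a number (the limit of > 100000 nM in this assay, at which 1 of the 2 values shown sits). Going by the values given here, the single measured step is therefore an at least 8.3-fold lower number from compound 1 to compound 2 (0.92 log units; beyond the scatter), with 4-fluorophenyl in place of cyclohexyl on an amide-type nitrogen.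

Compound 3 `O=C(CCc1cccc2c1B(O)OC2)Nc1cccc(I)c1` is the next entry and has yet to be run in this assay. It differs from compound 2 by 3-iodophenyl in place of 4-fluorophenyl on an amide-type nitrogen. Among the compounds with values here, the measured step from cyclohexyl to 4-fluorophenyl bears only loosely on an aryl-to-aryl exchange; no step among the measured compounds changes one halogen-bearing phenyl for another. The step from compound 2 to compound 3 is therefore expected to be small, as a 1.7-fold lower number from compound 2 to compound 3 (0.23 log units; within the scatter), with the lower number taken as the more likely side. Compound 3 is accordingly estimated at 7000 nM in this assay, within a range from 2000 nM to 30000 nM.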

Compound 3, half-maximal inhibitory concentration: 71000 nM
Compound 3: the middle estimate sits 10-fold (1.01 log units) below what was measured, and the stated range ends below it.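

At the amide-type nitrogen, exchanging one halogen-bearing phenyl for another is not a neutral change in this assay, and the step is a 5.9-fold higher number from compound 2 to compound 3 (0.77 log units; beyond the scatter); an aryl group at this place does not by itself fix the number, so the value of compound 2 cannot stand for aryl groups in general. Against cyclohexyl, the step is an at least 1.4-fold lower number from compound 1 to compound 3 (0.14 log units; that floor lies within the scatter), which gives only a floor and shows no separation beyond the scatter. Compound 1 stands at a limit and not at a number, and any comparison with it stays open-ended because of that: the limit of > 100000 nM in this assay, at which 1 of the 3 values shown sits.

3-iodophenyl and 4-fluorophenyl differ in both the halogen and its place on the ring, and the compounds shown do not separate the two. Also open, from the compounds shown here alone, is how the number responds to a benzyl group on the amide-type nitrogen, or to an amine or a carboxylic acid on the phenyl ring.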